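A few compounds are considered here, and "the series" means these few. Any claim that something is new, unique, unknown or untested is made for them only; others in the source may bear on it.

Measured in an in vitro ADME assay on microsomes from liver (Mus musculus) for metabolic stability, tested at 5 uM; a higher number here means that the compound lasts longer, a lower number that the compound disappears faster:
- Compound 1 `C=CC(=O)NCc1coc(-c2c(N)ncnc2Nc2ccc(Oc3cc(Cl)ccc3Cl)c(Cl)c2)n1`: 0.95 h
- Compound 2 `C=CC(=O)NCc1coc(-c2c(N)ncnc2Nc2ccc(Oc3ccc(F)cc3)c(Cl)c2)n1`: > 1.66 h (a limit)
- Compound 3 `C=CC(=O)NCc1coc(-c2c(N)ncnc2Nc2ccc(Oc3ccccn3)c(Cl)c2)n1`: 0.25 h

Of the two actual numbers, compound 1 at 0.95 h is the higher, and a 3.8-fold lower number from compound 1 to compound 3 (0.58 log units; beyond the scatter). Compound 2 gives > 1.66 h, which is a limit.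

Compound 4 `C=CC(=O)NCc1coc(-c2c(N)ncnc2Nc2ccc(F)c(Cl)c2)n1`, still unmeasured, carries fluoro in place of 2,5-dichlorophenoxy on an aromatic carbon. The measured steps only swap the ring on that oxygen and never remove it. They also point both ways: an at least 1.7-fold higher number from compound 1 to compound 2 (0.24 log units; that floor lies within the scatter), while an at least 6.6-fold lower number from compound 2 to compound 3 (0.82 log units; beyond the scatter). They therefore give no direction for this change, and no step beyond the scatter is expected in this assay. The expected step is a 1.1-fold higher number from compound 1 to compound 4 (0.02 log units; within the scatter). For compound 4 the estimate is 1 h, with an expected range of 0.35 h to 2.5 h.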

Compound 4, half-life: 0.15 h
Compound 4: the middle estimate sits 6.7-fold (0.82 log units) above what was measured; measured number below the stated range.
By their numbers in this assay, from the lowest: compounds 4 and 3 (each within the scatter of the next); then compound 1. At a limit, above all of these: compound 2.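

In this assay, going by these compounds alone, the earlier steps only swapped the ring on the oxygen, whereas removing the whole group matters: with fluoro in place of 2,5-dichlorophenoxy there is a 6.3-fold lower number from compound 1 to compound 4 (0.80 log units; beyond the scatter). Replacing 4-fluorophenoxy gives an at least 11-fold lower number from compound 2 to compound 4 (1.04 log units; beyond the scatter), and this step starts from a limit: the limit of > 1.66 h in this assay, at which 1 of the 4 values shown sits. Not every aryloxy group differs from fluoro here, since replacing (pyridin-2-yl)oxy gives a 1.7-fold lower number from compound 3 to compound 4 (0.22 log units; within the scatter).

Going by these compounds, what a methoxy group or an amine on this carbon would give stays open. So does whether any group without a ring can match compound 1.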